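The compounds below may be only part of what the source reports. "The series", "measured", "known", "first", "only" and "open" are said of these compounds alone.

Working notes on the series.

Of the compounds shown here, two of the shared core have been measured so far. Compound 1 `ClCc1cccc(Cn2cnc3nc(Cl)nc(Cl)c32)c1` gives 1690 nM in a functional assay on OVCAR-5 cells (Homo sapiens) for cytotoxicity, read by sulforhodamine B assay, with a stated time of 48 h; a higher number here means a weaker inhibitor of growth, a lower number a stronger inhibitor of growth. Compound 2 `ClCc1ccccc1Cn1cnc2nc(Cl)nc(Cl)c21` gives 2690 nM in this assay. Compound 1 stands at the lowest of the two numbers, but its nearest neighbour, compound 2, sits within the usual scatter of it, so the two cannot be ordered on these data. Within the data shown here, the two measured compounds differ in more than one place, so no single step between them is available, and nothing can yet be said about the weight of any one change on the core.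

The next compound to be run is compound 3 `ClCc1cccc(Cn2cnc3ncnc(Cl)c32)c1`. Relative to compound 1 it carries the change (hydrogen in place of chloro on an aromatic carbon). Among the measured compounds shown here, no measured pair isolates this change, so what to expect for it in this assay rests on compound 1 alone. The step from compound 1 to compound 3 is expected to be small, towards a higher number, and not clearly beyond the scatter, as a 1.8-fold higher number from compound 1 to compound 3 (0.25 log units; within the scatter). Compound 3 is accordingly estimated at 3000 nM, with a range of 1000 nM to 9000 nM.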

Compound 3, concentration for 50% growth inhibition: 6760 nM
Beside the measured number, compound 3's estimate is 2.3-fold (0.35 log units) below it; the range from low to high includes it.
By their numbers in this assay, from the lowest: compounds 1 and 2 (each within the scatter of the next); then compound 3.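

Among these compounds, this is the first step that isolates one change: in this assay, hydrogen in place of chloro on an aromatic carbon, between two ring nitrogen atoms, gives a 4.0-fold higher number from compound 1 to compound 3 (0.60 log units; beyond the scatter). The step is modest but lies beyond the scatter, so the chloro at this position carries measurable weight for growth inhibition, which compound 1 and compound 2 could not show, since they differ from each other in more than one place. No measurement at hand bears on the reason for this step.

Chloro and hydrogen are the only two groups shown at this position, so it remains open whether an amine, a methoxy group or a fluoro there would stay close to compound 1 or move towards compound 3. From the compounds shown here alone, it is also open whether the same change made on compound 2 would give a step of similar size, and whether the remaining chloro group on the same ring carries any comparable weight.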